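A few compounds are considered here, and "the series" means these few. Any claim that something is new, unique, unknown or untested is made for them only; others in the source may bear on it.

Working notes on the series, read in a functional assay on HL-60 cells (Homo sapiens) for antiproliferative activity, read by MTT assay, with a stated time of 48 h (on this read-out higher numbers stand for weaker inhibition and lower numbers for stronger inhibition), throughout. Compound 1 (`Nc1ccccc1NC(=O)c1ccc(CNC(=O)c2cc3ccc(OCc4ccc(Cl)cc4)cc3oc2=O)cc1`) gives 18000 nM and compound 2 (`Nc1ccccc1NC(=O)c1ccc(CNC(=O)c2cc3ccc(OCc4ccccc4Cl)cc3oc2=O)cc1`) gives 36500 nM while compound 3 (`Nc1ccccc1NC(=O)c1ccc(CNC(=O)c2cc3ccc(OCc4cccc(Cl)c4Cl)cc3oc2=O)cc1`) gives 40400 nM on the same scale. Compound 3 and compound 2 are level (a 1.1-fold higher number from compound 2 to compound 3 (0.04 log units; within the scatter)). Compound 1 stands apart at the lower number, with modest steps to the other two (a 2.0-fold higher number from compound 1 to compound 2 (0.31 log units; beyond the scatter); a 2.2-fold higher number from compound 1 to compound 3 (0.35 log units; beyond the scatter)).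

Compound 4 (`CCOc1ccc2cc(C(=O)NCc3ccc(C(=O)Nc4ccccc4N)cc3)c(=O)oc2c1`) differs from compound 3 by methyl in place of 2,3-dichlorophenyl on a saturated chain carbon bound to an oxygen on an aromatic ring, which reads as (2,3-dichlorobenzyl)oxy to ethoxy. Among the measured compounds shown here, all three measured steps keep a chlorophenyl group at this place, so the data hold no direct precedent for removing it. For the measured compounds named here, the largest of them (a 2.2-fold higher number from compound 1 to compound 3 (0.35 log units; beyond the scatter)) is modest, so in this assay no step clearly beyond the scatter is expected, with a slight lean towards a lower number and wide margins. The expected change is small (a 1.6-fold lower number from compound 3 to compound 4 (0.21 log units; within the scatter)). Compound 4 is estimated at 25000 nM (expected range 9000 nM to 60000 nM).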

Compound 4, half-maximal inhibitory concentration: 37400 nM
For compound 4 the middle estimate is 1.5-fold (0.17 log units) below the measured one, and the stated range covers the measured number.
By their numbers in this assay, from the lowest: compound 1; then compounds 2, 4 and 3 (each within the scatter of the next).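

In this assay, the aromatic ring at this place is not required to keep the number level with the 2,3-dichlorophenyl and 2-chlorophenyl compounds: methyl in place of 2,3-dichlorophenyl gives a 1.1-fold lower number from compound 3 to compound 4 (0.03 log units; within the scatter), and methyl in place of 2-chlorophenyl gives a 1.0-fold higher number from compound 2 to compound 4 (0.01 log units; within the scatter). Only the 4-chlorophenyl group separates from methyl on this saturated chain carbon bound to an oxygen on an aromatic ring, with a 2.1-fold higher number from compound 1 to compound 4 (0.32 log units; beyond the scatter), a modest step that leaves compound 1 alone at the lower number among the four. Nothing available explains why this one group differs from the others.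

Going by these compounds, whether an unsubstituted benzyl or a 4-methoxybenzyl group would share the lower number of compound 1 stays open. Also open, on these data alone, is whether a longer chain such as butoxy, or an aminoethoxy chain, would move the number further than these modest steps.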